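This account rests on a few compounds, and the source may have more. Where it says the series, first, only, none or still open, it means among the compounds named here.

Among the measured compounds shown here, compound 2 `CCCCN1CCN(CCCCn2c3c(c4ccccc42)C(=O)c2c[n+]([O-])c4ccccc4c2C3=O)CC1` stands lowest of the two numbers so far in a functional assay on MDA-MB-231 cells (Homo sapiens) for cytotoxicity, read by MTT assay, with a stated time of 72 h; on this read-out higher numbers stand for weaker inhibition and lower numbers for stronger inhibition. In this assay, for the measured compounds named here, compound 2 gives 900 nM, while compound 1 `CN1CCN(CCCCCCn2c3c(c4ccccc42)C(=O)c2c[n+]([O-])c4ccccc4c2C3=O)CC1` gives 2400 nM; the single step between them, a 2.7-fold lower number from compound 1 to compound 2 (0.43 log units; beyond the scatter), is the only measured change available, and it concerns the chain and its saturated ring rather than an aromatic group.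

Compound 3 `O=C1c2c[n+]([O-])c3ccccc3c2C(=O)c2c1c1ccccc1n2CCCCn1ccnc1` has not yet been tested. It differs from compound 2 in one place: 1H-imidazol-1-yl in place of 4-butylpiperazin-1-yl on a saturated chain carbon, four bonds along the chain from an aromatic nitrogen. Going by the values given here, no measured step involves a 1H-imidazol-1-yl group, so the comparison of compound 1 and compound 2 bears on this change only loosely, by showing that an alteration at this position of the chain moves the number modestly rather than dramatically. Given that, a change from compound 2 to compound 3 of about a 1.7-fold higher number from compound 2 to compound 3 (0.22 log units; within the scatter) is expected, most likely toward a somewhat higher number but possibly staying within the scatter. Compound 3 is therefore estimated to give 1500 nM in this assay, with a likely range from 500 nM to 4500 nM.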

Compound 3, half-maximal inhibitory concentration: 210 nM
Compound 3: the middle estimate sits 7.1-fold (0.85 log units) above what was measured; measured number below the stated range.
By their numbers in this assay, from the lowest: compound 3; then compound 2; then compound 1.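

In this assay, the step from the saturated ring to an aromatic one, 1H-imidazol-1-yl in place of 4-butylpiperazin-1-yl, gives a 4.3-fold lower number from compound 2 to compound 3 (0.63 log units; beyond the scatter), so this place on the chain can carry a much smaller five-membered aromatic ring without any loss, and the number in fact falls beyond the scatter. Among the compounds shown here, measured against the other piperazine compound, the same kind of replacement gives an 11-fold lower number from compound 1 to compound 3 (1.06 log units; beyond the scatter), the only step of large size so far, and compound 3 now lies below both piperazine compounds, so at this position the kind of ring moved the number further than the one earlier step among piperazines had. No evidence is available that explains why the imidazole compound gives the lowest number.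

The compounds shown leave open whether the drop follows from the aromatic ring itself or simply from the loss of the piperazine and its butyl group, a question that a 1H-pyrazol-1-yl, a 1H-1,2,4-triazol-1-yl or a piperidin-1-yl group at the same place would bear on. They also leave open how the 1H-imidazol-1-yl group behaves on a shorter or a longer chain, such as a hexyl chain.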